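Swapping a Piperidine Arm for a Sulfonamide Chain

This account rests on a few compounds, and the source may have more. Where it says the series, first, only, none or still open, it means among the compounds named here.

For the measured compounds named here, compound 2 `CC(=O)N1CCC(c2cncc(N3C(=O)c4ccc(Cl)cc4C3(C)C)c2)CC1` gives 5 nM in an assay on cells for inhibition of cytochrome P450 11B2, mitochondrial (Homo sapiens), read by HTRF (on this read-out lower numbers stand for stronger inhibition and higher numbers for weaker inhibition), the lowest of the two numbers measured so far; compound 1 `CC1(C)c2cc(Cl)ccc2C(=O)N1c1cccnc1` gives 108 nM. Going by the values given here, the one recorded step, a 22-fold lower number from compound 1 to compound 2 (1.33 log units; beyond the scatter), is large and came from adding a group at the same place that is now altered. Compound 3 `CC1(C)c2cc(Cl)ccc2C(=O)N1c1cncc(CNS(C)(=O)=O)c1` carries (methanesulfonamido)methyl in place of 1-acetylpiperidin-4-yl on an aromatic carbon. Among the compounds with values here, no measured step covers this particular exchange, so only the size of that earlier step guides the expectation. Compound 3 is expected to keep part of the gain, with an estimated step of a 5.0-fold higher number from compound 2 to compound 3 (0.70 log units; beyond the scatter), giving an expected 25 nM within a range from 8 nM to 80 nM.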

Compound 3, half-maximal inhibitory concentration: 33 nM
Compound 3: the middle estimate sits 1.3-fold (0.12 log units) below what was measured, and the stated range covers the measured number.
By their numbers in this assay, from the lowest: compound 2; then compound 3; then compound 1.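

In this assay, a chain without a ring still helps at this position: a 3.3-fold lower number from compound 1 to compound 3 (0.51 log units; beyond the scatter) shows that the gain over hydrogen is not confined to 1-acetylpiperidin-4-yl. Yet (methanesulfonamido)methyl keeps only part of that gain, with a 6.6-fold higher number from compound 2 to compound 3 (0.82 log units; beyond the scatter) showing that the two arms are not interchangeable here.

On these data alone, whether an amine or a carboxylic acid at this place would land nearer compound 2 or compound 1 stays open, as does which part of the sulfonamide chain carries the gain. Nothing available explains the difference between the two arms.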